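Replacing 1H-pyrazol-4-yl with 1-methyl-1H-imidazol-4-yl

This account rests on a few compounds, and the source may have more. Where it says the series, first, only, none or still open, it means among the compounds named here.

Of the compounds shown here, three on a shared core have so far been measured in a physicochemical assay for lipophilicity, at pH 7.4 (on this read-out lower numbers stand for lower lipophilicity and higher numbers for higher lipophilicity), and span a wide range. Compound 1 (`C[C@H]1C(=O)N(C)C=Cc2cc(C(O)CO)ccc21`) stands at 1.1 and compound 2 (`CCS(=O)(=O)c1ccc2c(c1)C(c1ccccc1)=CN(C)C(=O)C2C`) at 5.1 on this scale. Compound 3 (`CCOc1ccc2c(c1)C(c1cn[nH]c1)=CN(C)C(=O)[C@@H]2C`) reads 3.4 and is the second highest of the three numbers, lower than compound 2 and higher than compound 1, with both gaps beyond the scatter.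

Compound 4 (`CCOc1ccc2c(c1)C(c1cn(C)cn1)=CN(C)C(=O)[C@@H]2C`) carries 1-methyl-1H-imidazol-4-yl in place of 1H-pyrazol-4-yl on a double-bonded ring carbon and has not yet been measured. Within the data shown here, no measured pair differs in one place only, so the data offer no direct guide to this exchange. Both groups are five-membered aromatic rings with no net charge. Starting from compound 3 at 3.4 in this assay, a slight fall that stays within the scatter is expected. The estimated change is a number 0.20 log units lower from compound 3 to compound 4 (within the scatter) on this scale. For compound 4 the expected value is 3.2 with an estimated range of 2.6 to 3.7 on the same scale.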

Compound 4, distribution coefficient: 3.6
Compound 4: the middle estimate sits 0.40 log units below what was measured; measured number inside the range.
By their numbers in this assay, from the lowest: compound 1; then compounds 3 and 4 (each within the scatter of the next); then compound 2.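

In this assay, among these compounds, exchanging 1H-pyrazol-4-yl for 1-methyl-1H-imidazol-4-yl on the double-bonded ring carbon gives a number 0.20 log units higher from compound 3 to compound 4 (within the scatter), the first step in this set that changes one place only. At this position, the two groups cannot be told apart on this read-out, even though the leaving group carries a hydrogen-bond donor and the entering group carries none. Nothing available accounts for this result.

The step changes the ring and adds the methyl group together, so the compounds shown do not separate these two changes, which a 1-methyl-1H-pyrazol-4-yl group at this carbon could do. They also leave open how an amine or a carboxylic acid at this carbon would read, and whether the step would hold with another group in place of the ethoxy group.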